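Two ureas measured, a third awaiting its number

The source may report more compounds than this note shows. Statements on the series, on what has been measured and on what is new or still open speak of the compounds shown alone.

Two analogues of a shared core have been tested so far. Compound 1 `O=C(Nc1cccc(CNc2nccnc2Cl)c1)Nc1cccc2ccccc12` carries a naphthyl urea and gives 32700 nM in a functional assay on MGC-803 cells (Homo sapiens) for antiproliferative activity, read by MTT assay, with a stated time of 48 h; a lower number here means a stronger inhibitor, a higher number a weaker inhibitor. Compound 2 `O=C(Nc1cccc(CNc2nccnc2Cl)c1)Nc1ccccc1F`, with a 2-fluorophenyl on the same amide-type nitrogen, gives 6440 nM in this assay, the lowest of the two numbers shown and a gap to compound 1 that lies beyond the usual scatter. The next compound, compound 3 `O=C(Nc1cccc(CNc2nccnc2Cl)c1)Nc1ccc(Cl)c(Cl)c1`, differs from compound 2 in one place: 3,4-dichlorophenyl in place of 2-fluorophenyl on an amide-type nitrogen. For the measured compounds named here, no measured pair in the set isolates this kind of change, so its effect can only be guessed. A small step in this assay is expected, if anything toward a lower number, of about a 1.6-fold lower number from compound 2 to compound 3 (0.21 log units; within the scatter) from compound 2. Compound 3 is therefore estimated at 4000 nM in this assay, within a range of 1000 nM to 20000 nM.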

Compound 3, half-maximal inhibitory concentration: 4970 nM
Compound 3: the middle estimate sits 1.2-fold (0.09 log units) below what was measured, within the range that was stated.
By their numbers in this assay, from the lowest: compounds 3 and 2 (each within the scatter of the next); then compound 1.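

In this assay, 3,4-dichlorophenyl in place of 2-fluorophenyl on the amide-type nitrogen gives a 1.3-fold lower number from compound 2 to compound 3 (0.11 log units; within the scatter) and so cannot be told apart from compound 2. The earlier compounds shown here showed only a gap beyond the scatter, with compound 1 at 32700 nM and compound 2 at 6440 nM in this read-out, whereas this pair shows that two differently substituted phenyl groups at this position can give numbers within the scatter of each other. Nothing measured here bears on why this is so.

On these data alone, whether a phenyl group carrying an amine, a carboxylic acid or a methoxy group on this nitrogen would move the number beyond the scatter remains open. Also open, as far as these compounds go, is what a single chlorine would do, since the fluorine leaves and both chlorines enter in one step.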